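Pyrazoline sulfonamides: cytotoxicity on hamster kidney cells

The source may hold more compounds than are shown below. What is called first, only, known or untested is meant among the compounds shown, and "the series" means these compounds.

Measured so far:
compound 1, `NS(=O)(=O)c1ccc(N2N=C(c3ccc(OCc4ccccc4)cc3)CC2c2ccc(Cl)cc2)cc1`, 15000 nM
compound 2, `NS(=O)(=O)c1ccc(N2N=C(c3ccc(OCc4ccccc4)cc3)CC2c2ccccc2F)cc1`, 90000 nM
compound 3, `NS(=O)(=O)c1ccc(N2N=C(c3ccc(Oc4ccccc4)cc3)CC2c2ccccc2F)cc1`, 32000 nM

All three values come from an ADME assay on BHK-21 cells (Mesocricetus auratus) for cytotoxicity, read by MTT assay, with a stated time of 72 h; a higher number here means that more compound is tolerated, a lower number that less compound is tolerated. Compound 2 gives the highest number of the three, 90000 nM, and is tolerated best in this assay. Compound 3 stands second with 32000 nM, and compound 1 lowest with 15000 nM.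

Two single changes connect the measured compounds. From compound 2 to compound 1 the change is 4-chlorophenyl in place of 2-fluorophenyl on a saturated ring carbon, and it gives a 6.0-fold lower number from compound 2 to compound 1 (0.78 log units; beyond the scatter). From compound 2 to compound 3 the change is phenyl in place of benzyl on an oxygen on an aromatic ring, and it gives a 2.8-fold lower number from compound 2 to compound 3 (0.45 log units; beyond the scatter). Both steps lie beyond the usual scatter.

Compound 4, `NS(=O)(=O)c1ccc(N2N=C(c3ccc(Oc4ccccc4)cc3)CC2c2ccc(Cl)cc2)cc1`, has not yet been measured in this assay. It differs from compound 3 by 4-chlorophenyl in place of 2-fluorophenyl on a saturated ring carbon. This is the same change as that from compound 2 to compound 1, made on a core that differs from the core of compound 2 by phenyl in place of benzyl on an oxygen on an aromatic ring; the place of the change reads the same in both pairs.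

Within the data shown here, only one measured pair carries this change, so the expectation rests on it alone: because a 6.0-fold lower number from compound 2 to compound 1 (0.78 log units; beyond the scatter) lowered the number, a step of similar direction and somewhat smaller size, a 4.6-fold lower number from compound 3 to compound 4 (0.66 log units; beyond the scatter), is expected from compound 3 to compound 4. Compound 4 is accordingly estimated at 7000 nM, with a range from 2500 nM to 20000 nM.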

Compound 4, half-maximal cytotoxic concentration: 7000 nM
Beside the measured number, compound 4's estimate shows no gap at the digits printed; the measured number falls inside the stated range.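

In this assay, 4-chlorophenyl in place of 2-fluorophenyl on the saturated ring carbon gives a 4.6-fold lower number from compound 3 to compound 4 (0.66 log units; beyond the scatter), and this step agrees with its earlier counterpart: the same change on two cores in this assay, a 6.0-fold lower number (0.78 log units; beyond the scatter) from compound 2 to compound 1 and a 4.6-fold lower number (0.66 log units; beyond the scatter) from compound 3 to compound 4, 1.3-fold (0.12 log units) apart, within the scatter of two such steps
Phenyl in place of benzyl on the oxygen gives a 2.1-fold lower number from compound 1 to compound 4 (0.33 log units; beyond the scatter), and this step also agrees with its earlier counterpart: the same change on two cores in this assay, a 2.8-fold lower number (0.45 log units; beyond the scatter) from compound 2 to compound 3 and a 2.1-fold lower number (0.33 log units; beyond the scatter) from compound 1 to compound 4, 1.3-fold (0.12 log units) apart, within the scatter of two such steps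
Across compounds 1 to 4, each change therefore carries over from one core to the other in direction and, within the scatter, in size, but each rests on only two cores, so this shows neither that the same would hold on a further core nor why either change lowers the number.

The 4-chlorophenyl for 2-fluorophenyl swap alters both the halogen and its place on the ring, so 4-fluorophenyl and 2-chlorophenyl groups on the same saturated ring carbon would be needed to tell these two apart. Also open, going by these compounds, is how far the pattern extends to a longer chain such as phenethyl on the oxygen, or to a carboxylic acid or an amine on either of the outer rings.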